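The source may report more compounds than this note shows. Statements on the series, on what has been measured and on what is new or still open speak of the compounds shown alone.

In an ADME assay on HEK293 cells (Homo sapiens) for cytotoxicity, read by MTT assay, with a stated time of 72 h (on this read-out lower numbers stand for stronger inhibition and higher numbers for weaker inhibition), compound 2 `C=CCOc1cc(C2=C(c3cc(OC)c(OC)c(OC)c3)C(=O)C(O)C2)ccc1OC` gives only a limit of the assay, > 100 ug/mL, and not a number. Compound 1 `COc1cc(C2=C(c3cc(C)c(OC)c(C)c3)C(O)CC2=O)cc(OC)c1OC` likewise reaches only a limit, > 100 ug/mL. For compound 3 `COc1ccc(C2=C(c3cc(OC)c(OC)c(OC)c3)C(=O)C(OC(C)=O)C2)cc1` no result was reported, "not determined" (no result reported). For the measured compounds named here, two of the three entries sit at the same limit, (the limit of > 100 ug/mL in this assay, at which 2 of the 3 values shown sit), so no step between measured compounds can be read from these data. Compound 4 `COc1ccc(C2=C(c3cc(OC)c(OC)c(OC)c3)C(=O)C(O)C2)cc1F` differs from compound 2 in one place: fluoro in place of allyloxy on an aromatic carbon. With only limits to go on, no shift beyond the usual scatter is expected in this assay; the expected step that the limit leaves unreadable from compound 2 to compound 4 is essentially none. Compound 4 is therefore estimated at about 120 ug/mL in this assay, with a range from 40 ug/mL to 300 ug/mL.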

Compound 4, half-maximal inhibitory concentration: > 100 ug/mL
Compound 4 was reported as a limit (the forecaster's own chance of this, stated with the estimate: 70%); the middle value lies beyond the limit too.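

Compound 2 and compound 4 both stop at a limit of the assay, not a number, so no step between them can be read: the limit of > 100 ug/mL in this assay, at which 3 of the 4 values shown sit.

From the compounds shown here alone, whether fluoro in place of allyloxy changes anything in this assay stays open.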